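The compounds below may be only part of what the source reports. "The series", "measured", "known", "first", "only" and "open" are said of these compounds alone.

Notes on the series. Compound 1 `OC[C@H]1C=C(F)[C@@H](n2cnc3c(O)ncnc32)S1` carries hydrogen on the aromatic carbon in question; in a functional assay on CCRF-CEM cells (Homo sapiens) (on this read-out higher numbers stand for weaker inhibition and lower numbers for stronger inhibition), compound 1 returns only a limit of the assay, > 100000 nM. For the measured compounds named here, compound 2 `OC[C@H]1C=C(F)[C@@H](n2cnc3c(O)nc(F)nc32)S1` has fluoro there, and in this assay compound 2 gives 10400 nM, the only full number measured so far. The other value, that of compound 1, is a limit (the limit of > 100000 nM in this assay, at which 1 of the 2 values shown sits). Going by the values given here, the one measured step, an at least 9.6-fold lower number from compound 1 to compound 2 (0.98 log units; beyond the scatter), is the sole guide for what follows.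

Compound 3 `Nc1nc(O)c2ncn([C@H]3S[C@@H](CO)C=C3F)c2n1` is reached from compound 2 by amino in place of fluoro on an aromatic carbon. Among the compounds with values here, the measured step shows that this carbon tolerates a substituent and that a small change there can move the number well beyond the scatter, but no measured pair shows amino against fluoro, so its direction rests on the exchange itself. An amino group that adds a donor and an acceptor at this carbon is expected to give a step of a 3.5-fold lower number from compound 2 to compound 3 (0.54 log units; beyond the scatter) in this assay, toward a lower number, with wide uncertainty. For compound 3 the estimate in this assay is 3000 nM, within 300 nM to 30000 nM.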

Compound 3, half-maximal inhibitory concentration: 41500 nM
For compound 3 the middle estimate is 14-fold (1.14 log units) below the measured one; the measured number lies above the stated range.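

At this carbon, between two ring nitrogen atoms, amino and fluoro are not interchangeable in this assay: the exchange gives a 4.0-fold higher number from compound 2 to compound 3 (0.60 log units; beyond the scatter), so the one-atom change from fluorine to nitrogen moves the number beyond the scatter, and toward weaker inhibition. Amino nevertheless keeps part of what fluoro gained over hydrogen, with an at least 2.4-fold lower number from compound 1 to compound 3 (0.38 log units; beyond the scatter), so among the three compounds the order at this carbon runs from fluoro through amino to hydrogen, and a substituent of either kind gives a full number in this series. The hydrogen end of that order has no fixed size, since the value of compound 1 is a limit and not a number: the limit of > 100000 nM in this assay, at which 1 of the 3 values shown sits.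

The compounds shown leave open whether the lower number relative to hydrogen extends to other small groups at this carbon, such as chloro or methyl, and whether methylamino or dimethylamino would sit closer to amino or to fluoro. They also leave open whether the same order holds when the hydroxy group on the shared core is replaced by an amine.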